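One Methyl More on the Amine Chain

This account rests on a few compounds, and the source may have more. Where it says the series, first, only, none or still open, it means among the compounds named here.

Going by the values given here, compound 1 `CCCNC(=C\C(=O)/C=C/c1ccc(O)c(OC)c1)/C=C/c1ccc(O)c(OC)c1` stands highest of the two compounds measured so far. In a functional assay on EA.hy 926 cells (Homo sapiens), read by fluorescence, tested at 1 uM (on this read-out lower numbers stand for a weaker effect and higher numbers for a stronger effect at the one concentration tested), compound 1 gives 78%, while compound 2 `CC(=O)Oc1ccc(/C=C/C(=O)/C=C(/C=C/c2ccc(OC(C)=O)cc2)NCC(C)C)cc1` gives 60%, a gap beyond the usual scatter. Compound 3 `COc1cc(/C=C/C(=O)/C=C(/C=C/c2ccc(O)c(OC)c2)NCC(C)C)ccc1O` differs from compound 1 in one place: methyl in place of hydrogen on a saturated chain carbon bound to two saturated chain carbons, turning propylamino into isobutylamino. Among the compounds with values here, no two measured compounds differ in a single place, so no step of this kind is known here. The step of a number 6 percentage points lower from compound 1 to compound 3 (within the scatter) is expected to be small, at most a slight loss and probably within the scatter. Compound 3 is therefore estimated at 72%, within a range from 55% to 88%.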

Compound 3, a percentage reported as activity, at one concentration (the size of the read-out at that concentration, not a potency): 83%
For compound 3 the middle estimate is 11 percentage points below the measured one; the range from low to high includes it.
By their numbers in this assay, from the lowest: compound 2; then compounds 1 and 3 (each within the scatter of the next).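

In this assay, the change from propylamino to isobutylamino gives a number 5 percentage points higher from compound 1 to compound 3 (within the scatter), so this first step read at this position shows that a methyl in place of hydrogen on the amine chain leaves the read-out within the usual scatter. One step at one concentration cannot show more than that. Nothing measured here accounts for this outcome. On these data alone, it remains open whether a longer chain, such as pentylamino, or a chain ending in a carboxylic acid would keep the read-out at this level.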